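A few compounds are considered here, and "the series" means these few. Any claim that something is new, unique, unknown or untested is made for them only; others in the source may bear on it.

Working notes on the series in a functional assay on CHO cells with adenosine receptor A1 (Homo sapiens) as the target, read by cAMP accumulation and immunoassay, with a stated time of 6 min, tested at 10 uM; a higher number here means a weaker effect of the compound at the concentration tested, a lower number a stronger effect. Compound 1 `Nc1scc(CN2CCN(c3ccc([N+](=O)[O-])cc3)CC2)c1C(=O)c1ccc(Cl)cc1` gives -17%, the highest of the three numbers in hand, its nearest neighbour being compound 2 at a gap beyond the scatter. Compound 2 `Nc1scc(CN2CCC(c3ccc(Cl)cc3)CC2)c1C(=O)c1ccc(Cl)cc1` gives -61% in this assay. Compound 3 `Nc1scc(CN2CCN(c3cccc(F)c3)CC2)c1C(=O)c1cccc(C(F)(F)F)c1` gives -62% in this assay, the gap from compound 1 also beyond the scatter. Compound 4 `Nc1scc(CN2CCN(C3CCCCCC3)CC2)c1C(=O)c1ccc(Cl)cc1` is not yet measured; relative to compound 1 the change is cycloheptyl in place of 4-nitrophenyl on an amine nitrogen in a ring. Within the data shown here, no measured pair shares this change, so its size is open. The step from compound 1 to compound 4 in this assay is expected to be a number 18 percentage points lower from compound 1 to compound 4 (beyond the scatter), a move towards lower numbers, probably beyond the scatter. For compound 4 the estimate is -35%, within -65% to -5%.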

Compound 4, a percentage reported as activity, at one concentration (the size of the read-out at that concentration, not a potency): -25%
Beside the measured number, compound 4's estimate is 10 percentage points below it; the range from low to high includes it.
By their numbers in this assay, from the lowest: compounds 3 and 2 (each within the scatter of the next); then compounds 4 and 1 (each within the scatter of the next).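

In this assay, cycloheptyl in place of 4-nitrophenyl on an amine nitrogen in a ring gives a number 8 percentage points lower from compound 1 to compound 4 (within the scatter). Among these compounds, at this position, then, a seven-membered non-aromatic carbon ring with no hydrogen-bond acceptors and an aromatic ring carrying a nitro group give values within the scatter of each other, which no earlier pair could show. Nothing measured here bears on why the two groups read alike.
Open, as far as these compounds go, is whether a smaller carbon ring such as cyclopentyl, or a benzyl group, on this nitrogen would stay as close to compound 1.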